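Swapping fluoro for methyl on the pendant phenyl

The source may report more compounds than this note shows. Statements on the series, on what has been measured and on what is new or still open speak of the compounds shown alone.

Compound 3 `CC1CCN(c2nc(C(F)(F)F)ccc2CNC(=O)C(c2ccc(F)cc2)c2ccc(NS(C)(=O)=O)c(F)c2)CC1` gives 3.4 nM in an assay on CHO cells for antagonist activity at transient receptor potential cation channel subfamily V member 1 (Homo sapiens), read by FLIPR; on this read-out lower numbers stand for stronger inhibition and higher numbers for weaker inhibition. Among the three measured compounds it holds the second highest number: compound 1 `CCC(C(=O)NCc1ccc(C(F)(F)F)nc1N1CCC(C)CC1)c1ccc(NS(C)(=O)=O)c(F)c1` gives 1.6 nM, and compound 2 `CC1CCN(c2nc(C(F)(F)F)ccc2CNC(=O)C(c2ccc(NS(C)(=O)=O)c(F)c2)C2CCCC2)CC1` gives 88.7 nM. Compound 4 `Cc1ccc(C(C(=O)NCc2ccc(C(F)(F)F)nc2N2CCC(C)CC2)c2ccc(NS(C)(=O)=O)c(F)c2)cc1` differs from compound 3 by methyl in place of fluoro on an aromatic carbon, so that a 4-fluorophenyl becomes a 4-methylphenyl. Among the measured compounds shown here, none of the measured steps touches this position; they change the group on the saturated chain carbon instead, where a 2.1-fold higher number from compound 1 to compound 3 (0.33 log units; beyond the scatter) was modest and a 26-fold lower number from compound 2 to compound 3 (1.42 log units; beyond the scatter) was large. Those steps give no direct guide to the aromatic fluoro. For the measured compounds named here, with no comparable step available, for compound 4 no change beyond the scatter is expected, a 1.3-fold higher number from compound 3 to compound 4 (0.12 log units; within the scatter). The estimate for compound 4 is 4.5 nM, ranging from 1.5 nM to 14 nM.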

Compound 4, inhibition constant: 1.1 nM
Beside the measured number, compound 4's estimate is 4.1-fold (0.61 log units) above it; the measured number lies below the stated range.
By their numbers in this assay, from the lowest: compounds 4 and 1 (each within the scatter of the next); then compound 3; then compound 2.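

Methyl in place of fluoro brings a 3.1-fold lower number from compound 3 to compound 4 (0.49 log units; beyond the scatter) as a modest step, so this aromatic position responds to the swap of a single heavy atom. Against ethyl on the chain carbon, 4-methylphenyl shows a 1.5-fold lower number from compound 1 to compound 4 (0.16 log units; within the scatter) and so no real difference, while against cyclopentyl it shows an 81-fold lower number from compound 2 to compound 4 (1.91 log units; beyond the scatter) and a large gain. No evidence here says why methyl reads better than fluoro. Still open, on these data alone, is how chloro, methoxy or an amine would read on this aromatic carbon, and whether methyl elsewhere on this ring would read alike.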